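A few compounds are considered here, and "the series" means these few. Any claim that something is new, unique, unknown or untested is made for them only; others in the source may bear on it.

Measured in a functional assay on HeLa cells (Homo sapiens) for antiproliferative activity, read by MTT assay, with a stated time of 72 h; on this read-out higher numbers stand for weaker inhibition and lower numbers for stronger inhibition:
- compound 1 `COc1cc(-n2ncnc2-c2ccc(Cl)c(Cl)c2)cc(OC)c1OC` gives > 10000 nM (a limit)
- compound 2 `CCOc1ccc(-c2ncnn2-c2cc(OC)c(OC)c(OC)c2)cc1` gives 15 nM
- compound 3 `COc1cc(-n2ncnc2-c2cccc(F)c2)cc(OC)c1OC` gives > 10000 nM (a limit)

In this assay compound 3 reports only the limit > 10000 nM and no number. Compound 3 and compound 1 share the limit of > 10000 nM in this assay, at which 2 of the 3 values shown sit, and only compound 2 gives a number.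

The step under consideration leads to compound 4 `COc1cc(-n2ncnc2-c2ccc(SC)cc2)cc(OC)c1OC` and puts 4-(methylsulfanyl)phenyl in place of 3-fluorophenyl on an aromatic carbon. The new group sits on an aromatic carbon of a five-membered aromatic ring with 3 nitrogen.

Within the data shown here, the one measured step that bears on this is a step that the two limits leave unreadable from compound 1 to compound 3 and it gives no size to carry over. The expectation therefore rests on compound 2 at 15 nM and on the aryl group of compound 4, which by structure stands closer to that of compound 2 than to those of compound 1 and compound 3. Among the measured compounds shown here, no measured step links compound 2 with compound 4, and the range stays wide. A large move toward stronger inhibition is expected, estimated as an at least 160-fold lower number from compound 3 to compound 4 (2.22 log units; beyond the scatter) in this assay here. Compound 4 is estimated at 60 nM, with an expected range from 8 nM to 1500 nM overall.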

Compound 4, half-maximal inhibitory concentration: 150 nM
Estimate against measurement, compound 4: 2.5-fold (0.40 log units) below; low and high end bracket the measured number.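

In this assay the 4-(methylsulfanyl)phenyl group, on an aromatic carbon of a five-membered aromatic ring with 3 nitrogen, gives a readable number on the shared core, with an at least 66-fold lower number from compound 3 to compound 4 (1.82 log units; beyond the scatter) and an at least 66-fold lower number from compound 1 to compound 4 (1.82 log units; beyond the scatter) as large steps beyond the scatter. The earlier step between 3,4-dichlorophenyl and 3-fluorophenyl cannot be read, and compound 1 and compound 3 remain limits rather than numbers: the limit of > 10000 nM in this assay, at which 2 of the 4 values shown sit. The ethoxy and methylsulfanyl groups now give the first step between two numbers, with a 10-fold higher number from compound 2 to compound 4 (1.00 log units; beyond the scatter) as a modest change beyond the scatter, and among these four compounds only the two carrying one of these groups give numbers, while the two carrying chlorine or fluorine stay at the limit.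

From the compounds shown here alone, it remains open whether a plain phenyl, 4-methoxyphenyl or 4-(dimethylamino)phenyl group would also give a number at this position, and whether a longer chain such as propoxy or butylsulfanyl would move it further. Also open, going by these compounds, is how far a single 4-chlorophenyl group would differ from 3,4-dichlorophenyl, since that comparison would separate the effect of the halogen from the effect of where it sits.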